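The source may hold more compounds than are shown below. What is called first, only, known or untested is meant among the compounds shown, and "the series" means these compounds.

Measured compounds:
compound 1, `Cc1nn(C)c2c1C(c1ccccc1)=NCC(=O)N2`, 10 mg/kg
compound 2, `CCc1nn(C)c2c1C(c1ccccc1)=NCC(=O)N2`, 2.5 mg/kg
compound 3, `Cc1nn(C)c2c1C(c1ccccc1Cl)=NCC(=O)N2`, 2.5 mg/kg

All values are from a functional assay on the whole organism (strain Holtzman) with Rattus norvegicus as the target; on this read-out higher numbers stand for an effect only at larger amounts of compound and lower numbers for an effect already at smaller amounts. Compound 2 differs from compound 1 by methyl in place of hydrogen on a saturated chain carbon bound to an aromatic carbon, which gave a 4.0-fold lower number from compound 1 to compound 2 (0.60 log units; beyond the scatter). The core of compound 3 differs from that of compound 1 by chloro in place of hydrogen on an aromatic carbon, with a 4.0-fold lower number from compound 1 to compound 3 (0.60 log units; beyond the scatter). Compound 2 and compound 3 lie within the scatter of each other in this assay.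

Compound 4, `CCn1nc(C)c2c1NC(=O)CN=C2c1ccccc1Cl`, is not yet measured and differs from compound 3 by methyl in place of hydrogen on a saturated chain carbon bound to an aromatic nitrogen. This is the same kind of change as that from compound 1 to compound 2, but not the same: there the place was a saturated chain carbon bound to an aromatic carbon, here a saturated chain carbon bound to an aromatic nitrogen. Within the data shown here, with only one such step known, and at a different place, the expected step for compound 4 is a smaller one, a 2.1-fold lower number from compound 3 to compound 4 (0.32 log units; beyond the scatter), leaning on a 4.0-fold lower number from compound 1 to compound 2 (0.60 log units; beyond the scatter). Compound 4 is estimated at 1.2 mg/kg, expected between 0.4 mg/kg and 5 mg/kg.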

Compound 4, minimum effective dose: 5 mg/kg
Compound 4: the middle estimate sits 4.2-fold (0.62 log units) below what was measured; low and high end bracket the measured number.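

Read in this assay the methyl in place of hydrogen on a saturated chain carbon bound to an aromatic nitrogen gives a 2.0-fold higher number from compound 3 to compound 4 (0.30 log units; within the scatter) and so does not repeat the earlier step, made on another core at a saturated chain carbon bound to an aromatic carbon: the same change on two cores in this assay, a 4.0-fold lower number (0.60 log units; beyond the scatter) from compound 1 to compound 2 and a 2.0-fold higher number (0.30 log units; within the scatter) from compound 3 to compound 4, 8.0-fold (0.90 log units) apart, beyond the scatter of two such steps
This change therefore cannot be carried from one core to another here on the strength of one step. Place and core both differ between the two steps, so the pair does not show which of them goes with the gap.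

Open, going by these compounds, is whether a longer chain such as propyl on the aromatic nitrogen follows compound 4. Also open, on these data alone, is how fluoro in place of chloro on the aromatic carbon compares with compound 3.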